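From 2-methylprop-1-en-1-yl to isobutyl on a shared core

This account rests on a few compounds, and the source may have more. Where it says the series, first, only, none or still open, it means among the compounds named here.

Measured so far:
compound 1, `CC(C)=CCOc1cccc(O)c1C(=O)/C=C/c1ccc(O)cc1`; in a functional assay on ACHN cells (Homo sapiens) for antiproliferative activity, read by sulforhodamine B assay (a lower number here means a stronger inhibitor of growth, a higher number a weaker inhibitor of growth), compound 1 gives > 30000 nM
compound 2, `O=C(/C=C/c1ccc(O)cc1)c1c(O)cccc1OCc1ccccc1`; in this assay compound 2 gives > 30000 nM

Compound 1 stands only at a limit of the assay, not at a number: its result in this assay is a limit. The same holds for compound 2, whose result in this assay is also a limit. Compound 2 differs from compound 1 by a phenyl in place of 2-methylprop-1-en-1-yl on a saturated chain carbon bound to an oxygen on an aromatic ring, and the step that the two limits leave unreadable from compound 1 to compound 2 cannot be read, because of the limit of > 30000 nM in this assay, at which 2 of the 2 values shown sit. No measured value in this series rises above that floor.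

Compound 3 is `CC(C)CCOc1cccc(O)c1C(=O)/C=C/c1ccc(O)cc1`. It differs from compound 1 as follows: isobutyl in place of 2-methylprop-1-en-1-yl on a saturated chain carbon bound to an oxygen on an aromatic ring. Going by the values given here, the only measured step touches the same place but is unreadable, so no measured step sizes this change. Compound 3 is therefore expected to remain where compound 1 sits, with no step beyond the scatter readable, and most probably to return another limit. The estimate for compound 3 in this assay is 45000 nM, with a range from 15000 nM to 150000 nM. That estimate means an expected step that the limit leaves unreadable from compound 1 to compound 3.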

Compound 3, concentration for 50% growth inhibition: 11300 nM
Estimate against measurement, compound 3: 4.0-fold (0.60 log units) above; measured number below the stated range.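

Replacing the 3-methylbut-2-en-1-yl chain of compound 1 with isopentyl shows that a change at this position can give a measured number: in this assay, compound 3 gives 11300 nM, the only number shown in the series. The change is an at least 2.6-fold lower number from compound 1 to compound 3 (0.42 log units; beyond the scatter), and exchanging the phenyl of the benzyl-type chain for isobutyl gives an at least 2.6-fold lower number from compound 2 to compound 3 (0.42 log units; beyond the scatter), so the isopentyl chain is separated from both other chains by more than the scatter. Both sizes are only lower bounds, because each step starts from a limit and not from a number: the limit of > 30000 nM in this assay, at which 2 of the 3 values shown sit.

With one number in this assay, the compounds shown give no trend along this chain, and they leave open how a longer chain such as octyl would compare with the isopentyl of compound 3. They also leave open what an amine or a carboxylic acid at the end of the chain would do, and whether any change at this position could carry growth inhibition much further than compound 3 does.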